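Replacing thiophen-2-yl with 2,4,6-trihydroxyphenyl in the series

A few compounds are considered here, and "the series" means these few. Any claim that something is new, unique, unknown or untested is made for them only; others in the source may bear on it.

In a functional assay on DU-145 cells (Homo sapiens) for inhibition, read by trypan blue exclusion, with a stated time of 96 h (a lower number here means a stronger inhibitor of growth, a higher number a weaker inhibitor of growth), compound 1 (`CC(=O)Oc1ccc(/C=C(\C(=O)c2ccc(Cl)cc2)S(=O)(=O)c2ccc(C)cc2)cc1`) gives 25000 nM. Among the measured compounds shown here, compound 2 (`Cc1ccc(S(=O)(=O)/C(=C/c2cccs2)C(=O)c2ccc(Cl)cc2)cc1`) gives 25000 nM, which places it level with compound 1 at the reported digits and leaves no separation between the two measured members.

The next compound is compound 3 (`Cc1ccc(S(=O)(=O)/C(=C/c2c(O)cc(O)cc2O)C(=O)c2ccc(Cl)cc2)cc1`), and the change from compound 2 is 2,4,6-trihydroxyphenyl in place of thiophen-2-yl on a double-bonded chain carbon bound to a double-bonded chain carbon. It falls on a double-bonded chain carbon bound to a double-bonded chain carbon, the same place that differs between the two measured compounds.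

For the measured compounds named here, only one measured step bears on this place: no change at the digits printed from compound 1 to compound 2 (within the scatter). Going by the values given here, with that step as the sole guide, no shift beyond the scatter is the central expectation in this assay. Among the compounds with values here, the basis is thin, however, as no measured compound carries the 2,4,6-trihydroxyphenyl group and the data give no direct reading of it. The range is therefore kept wide, and it extends further toward stronger inhibition of growth.

The expected step is a 1.7-fold lower number from compound 2 to compound 3 (0.22 log units; within the scatter), not clearly beyond the scatter. Compound 3 is estimated at 15000 nM, with an expected range of 3000 nM to 50000 nM.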

Compound 3, concentration for 50% growth inhibition: > 100000 nM
Compound 3 was reported as a limit; the forecaster's own chance of this, stated with the estimate: 15%; at least 6.6-fold (0.82 log units) between middle value and limit.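

Compound 3 gives > 100000 nM in this assay, a limit of the assay and not a number. The earlier pair showed no response to the group on a double-bonded chain carbon bound to a double-bonded chain carbon, with no change at the digits printed from compound 1 to compound 2 (within the scatter), whereas the 2,4,6-trihydroxyphenyl group does move the read-out in this assay, with an at least 4.0-fold higher number from compound 2 to compound 3 (0.60 log units; beyond the scatter) and an at least 4.0-fold higher number from compound 1 to compound 3 (0.60 log units; beyond the scatter), so this place is not indifferent to every group it carries. Both new steps point toward weaker inhibition of growth, and their full size stays unknown: the limit of > 100000 nM in this assay, at which 1 of the 3 values shown sits.

The compounds shown leave open whether the loss follows the three hydroxy groups together or a single one of them, and an unsubstituted phenyl or a phenyl carrying methoxy groups in place of the hydroxy groups would help separate those readings. Also open, as far as these compounds go, is whether any group at this place can give a lower number in this assay than the level shared by compound 1 and compound 2, since the change read here runs in one direction only.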